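Pyrrolidin-1-yl for dimethylamino on a well-tolerated compound

The source may report more compounds than this note shows. Statements on the series, on what has been measured and on what is new or still open speak of the compounds shown alone.

In a toxicity assay on HepG2 cells (Homo sapiens) for inhibition, read by resazurin assay, with a stated time of 24 h (a higher number here means that more compound is tolerated, a lower number that less compound is tolerated), compound 3 (`CN(C)C(=O)c1ncc([N+](=O)[O-])[nH]1`) gives > 100000 nM as a limit and not a number. Compound 1 (`CN(C)C(=O)c1ncc([N+](=O)[O-])n1C`) gives > 100000 nM which is also a limit. Compound 2 (`Cn1c([N+](=O)[O-])cnc1C(=O)N1CCCC1`) gives > 100000 nM which is a limit too.

Compound 4 (`O=C(c1ncc([N+](=O)[O-])[nH]1)N1CCCC1`) carries pyrrolidin-1-yl in place of dimethylamino on a carbonyl carbon.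

The same swap on the methylated compound is a step that the two limits leave unreadable from compound 1 to compound 2 and the other measured change is a step that the two limits leave unreadable from compound 1 to compound 3 so neither has a readable size. All that the data offer is the limit of > 100000 nM in this assay, at which 3 of the 3 values shown sit, and that points to no direction.

No step beyond the scatter is expected, and the estimated change is a number no higher from compound 3 to compound 4 (the limit leaves the size open) in this assay as a result.

For compound 4 the expected value is 100000 nM with an estimated range from 60000 nM to 200000 nM and a limit is again the expected outcome.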

Compound 4, half-maximal cytotoxic concentration: > 100000 nM
Compound 4 was reported as a limit; the forecaster's own chance of this, stated with the estimate: 90%; the middle value lies on the limit itself.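

Compound 4 gives > 100000 nM which is again a limit, so its steps from compound 3 and from compound 2 cannot be read. Whether either change shifts tolerance at all in this assay stays open: the limit of > 100000 nM in this assay, at which 4 of the 4 values shown sit.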